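The source may hold more compounds than are shown below. What is called first, only, known or untested is meant among the compounds shown, and "the series" means these compounds.

Measured so far:
- compound 1, `Cc1[nH]cnc1CN1CCN(c2cc(Cl)cc(Cl)c2)C1=O`: 5.62 nM
- compound 2, `Cc1[nH]cnc1CN1CCN(c2cccc(C#N)c2)C1=O`: 134 nM

In a functional assay (Cavia porcellus) for antagonist activity at Serotonin 3 (5-HT3) receptor (Homo sapiens) (a higher number here means a weaker inhibitor, a lower number a stronger inhibitor), compound 1 gives 5.62 nM, and in this assay compound 2 gives 134 nM. Among the measured compounds shown here, compound 2 thus holds the higher of the two numbers; the gap to compound 1 is beyond the scatter, and no single-point step links the two, so their values are only compared, not explained.

Compound 3, `COc1cccc(N2CCN(Cc3nc[nH]c3C)C2=O)c1`, is not yet measured. It differs from compound 2 in one place: methoxy in place of cyano on an aromatic carbon.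

For the measured compounds named here, no measured pair shows this change, so its effect is unknown from the data. The expectation is for a step from compound 2 to compound 3 of a 1.7-fold lower number from compound 2 to compound 3 (0.22 log units; within the scatter), small and likely within the scatter, with a slight lean towards a lower number. Compound 3 is therefore expected to give about 80 nM in this assay, with a range from 20 nM to 400 nM.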

Compound 3, antagonist equilibrium constant: 67.8 nM
Compound 3: middle estimate off by 1.2-fold (0.07 log units), on the high side, and the stated range covers the measured number.
By their numbers in this assay, from the lowest: compound 1; then compounds 3 and 2 (each within the scatter of the next).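

Among the compounds shown here, replacing cyano with methoxy on an aromatic carbon meta to a large group gives a 2.0-fold lower number from compound 2 to compound 3 (0.30 log units; within the scatter) in this assay, the first step that differs in one place. The step is within the scatter, so the data do not separate compound 2 from compound 3, and at this position a triple bond outside aromatic rings can give way to methoxy without a step beyond it. No measurement available here speaks to the reason for the size of this step.

Still open, on these data alone, is whether a lone chloro at this aromatic carbon would connect compound 2 and compound 3 to compound 1 through a single change. It is also unknown whether an amine, a carboxylic acid or a longer chain such as butoxy would remain within the scatter of these two compounds.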